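Swapping acetyl for methylsulfonyl at a clearance limit

The source may hold more compounds than are shown below. What is called first, only, known or untested is meant among the compounds shown, and "the series" means these compounds.

Measured in an ADME assay on microsomes from liver (Homo sapiens) for metabolic stability, read by LC-MS, using NADPH, with stated times of 10 min and 30 min; on this read-out lower numbers stand for slow clearance and higher numbers for fast clearance:
- Compound 1 `CC(=O)N[C@@H]1CCCc2c1cncc2N1C(=O)c2ccc(Cl)cc2[C@H]1C`: < 3.5 mL/min/kg
- Compound 2 `CC(=O)N[C@@H]1CCCc2c1cncc2N1Cc2cc(Cl)ccc2C1=O`: < 3.5 mL/min/kg
- Compound 3 `CC[C@H]1c2cc(Cl)ccc2C(=O)N1c1cncc2c1CCC[C@H]2NC(C)=O`: < 3.5 mL/min/kg

Compound 2 stands at < 3.5 mL/min/kg, which is a limit of the assay and not a number. The same is true of the entries for compound 1 and compound 3, so the whole series rests on (the limit of < 3.5 mL/min/kg in this assay, at which 3 of the 3 values shown sit).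

The next compound is compound 4 `CS(=O)(=O)N[C@@H]1CCCc2c1cncc2N1Cc2cc(Cl)ccc2C1=O`, which keeps the core of compound 2 and changes one group: methylsulfonyl in place of acetyl on an amine nitrogen. In words, methylsulfonyl takes the place of acetyl on an amine nitrogen, turning acetamido into methanesulfonamido.

Two measured steps are available, and both alter a group on a saturated ring carbon rather than on the amine nitrogen. For the measured compounds named here, the first is a step that the two limits leave unreadable from compound 1 to compound 2. The second is a step that the two limits leave unreadable from compound 2 to compound 3. Neither has a readable size, so they offer only weak guidance here. Going by the values given here, they show only that these changes left the values at the limit. No step beyond the usual scatter is therefore expected in this assay, in either direction. The expected result is a step that the limit leaves unreadable from compound 2 to compound 4. For compound 4 the estimated value is 3 mL/min/kg, with an expected range from 1.5 mL/min/kg to 6.5 mL/min/kg.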

Compound 4, clearance: < 3.5 mL/min/kg
Compound 4: a limit, no number; the forecaster's own chance of this, stated with the estimate: 70%; the middle value does not contradict the limit.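

Compound 2 and compound 4 both stand at a limit of the assay and not at a number, so the step between them cannot be read in this assay: the limit of < 3.5 mL/min/kg in this assay, at which 4 of the 4 values shown sit.

The compounds shown leave open how fast any of them is actually cleared, and whether methylsulfonyl in place of acetyl on an amine nitrogen changes clearance at all.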